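Fluoro for hydroxy on the pyrimidine of compound 3

A few compounds are considered here, and "the series" means these few. Any claim that something is new, unique, unknown or untested is made for them only; others in the source may bear on it.

Compound 3 `CS(=O)(=O)c1ccc2c(c1)CCN2c1ncnc2c(C3CCN(c4ncc(O)cn4)CC3)coc12` sits in the middle of a set of three that share a core and differ only in the group on the pyrimidine ring. In a functional assay on cells for agonist activity at Glucose-dependent insulinotropic receptor (Homo sapiens), read by a luciferase reporter, with a stated time of 4 h (on this read-out lower numbers stand for smaller maximal responses and higher numbers for larger maximal responses), compound 3 gives 145%, the second highest of the three numbers. Compound 2 `COc1cnc(N2CCC(c3coc4c(N5CCc6cc(S(C)(=O)=O)ccc65)ncnc34)CC2)nc1` gives 186%, and the step of a number 41 percentage points lower from compound 2 to compound 3 (beyond the scatter) is beyond the scatter. Compound 1 `CC(O)c1cnc(N2CCC(c3coc4c(N5CCc6cc(S(C)(=O)=O)ccc65)ncnc34)CC2)nc1` gives 33%, the lowest, and the step of a number 112 percentage points higher from compound 1 to compound 3 (beyond the scatter) is also large.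

Compound 4 `CS(=O)(=O)c1ccc2c(c1)CCN2c1ncnc2c(C3CCN(c4ncc(F)cn4)CC3)coc12` is not yet measured. It differs from compound 3 by fluoro in place of hydroxy on an aromatic carbon.

Within the data shown here, no measured step swaps hydroxy for fluoro at this carbon, so the two neighbouring steps are the only guide: the step from compound 1 to compound 3 was very large, and the step from compound 2 to compound 3 was clearly beyond the scatter. Among the measured compounds shown here, every change at this position so far has moved the maximal response by a large amount, and the only compound without a donor at that place, compound 2, gave the highest number. Compound 4 is therefore expected to show a step of about a number 5 percentage points higher from compound 3 to compound 4 (within the scatter), with the direction uncertain. The estimate for compound 4 is 150%, expected to fall between 90% and 220%.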

Compound 4, largest response reached (Emax), in percent of the reference or control that the assay uses: 229%
Compound 4: the middle estimate sits 79 percentage points below what was measured; the measured number lies above the stated range.
By their numbers in this assay, from the lowest: compound 1; then compound 3; then compound 2; then compound 4.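

In this assay, among these compounds, compound 4 has the highest number of the four compounds, and fluoro is the first group to pass methoxy at this aromatic carbon, with a number 43 percentage points higher from compound 2 to compound 4 (beyond the scatter), while replacing hydroxy gives a number 84 percentage points higher from compound 3 to compound 4 (beyond the scatter). Among the compounds shown here, this shows that a group counted with 0 hydrogen-bond donors and 0 hydrogen-bond acceptors can give the largest maximal response here, and the range of response reached through this single position is wider than the earlier compounds showed, with a number 196 percentage points higher from compound 1 to compound 4 (beyond the scatter). The two compounds without a hydroxy on the group at this place, compound 2 and compound 4, stand above the two with one, compound 1 and compound 3, and none of the four goes against this order, but nothing given here explains it.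

The compounds shown leave open whether chloro or a nitrile at this carbon would reach the same level as fluoro, or whether an amine or a carboxylic acid there would fall nearer the hydroxy compounds. They also leave open whether the order of these groups would hold with a different group elsewhere on the shared core.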